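Notes on the amine change from compound 3 to compound 4

The source may hold more compounds than are shown below. What is called first, only, known or untested is meant among the compounds shown, and "the series" means these compounds.

Measured compounds:
- compound 1: `COc1ccc(CNc2ncc(C(=O)O)c3nc(-c4ccco4)nn23)cc1OC` — 159 nM
- compound 2: `O=C(Nc1ncc(C(=O)O)c2nc(-c3ccco3)nn12)NC1CCCCC1` — 59400 nM
- compound 3: `CCOC(=O)c1cnc(NC2CC2)n2nc(-c3ccco3)nc12` — 9.52 nM

All three were run in an assay on CHO cells for displacement of a labelled ligand from adenosine receptor A3 (Homo sapiens); on this read-out lower numbers stand for stronger inhibition and higher numbers for weaker inhibition. Compound 3 has the lowest number of the three in this assay, at 9.52 nM; compound 1 lies well above it, beyond the scatter, and compound 2 lies very far above it. None of these measured pairs differ in a single place, so no measured gap can be tied to one change, and the rest of each structure varies alongside the amine.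

Compound 4 `CCOC(=O)c1cnc(NCC2CCCCC2)n2nc(-c3ccco3)nc12` is the unmeasured entry. It differs from compound 3 in one place: cyclohexylmethyl in place of cyclopropyl on a nitrogen on an aromatic ring. The remainder of the structure is unchanged, and the exchange adds no donor or acceptor.

For the measured compounds named here, with no measured step of this kind, the size of the move has no anchor. The expectation is a small shift, at most a modest weakening, plausibly within the scatter, as a 1.6-fold higher number from compound 3 to compound 4 (0.20 log units; within the scatter). Compound 4 is expected at 15 nM, in the range 3 nM to 80 nM.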

Compound 4, inhibition constant: 41.2 nM
Beside the measured number, compound 4's estimate is 2.7-fold (0.44 log units) below it; low and high end bracket the measured number.
By their numbers in this assay, from the lowest: compound 3; then compound 4; then compound 1; then compound 2.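

In this assay, the series now has its first single-place step: cyclohexylmethyl in place of cyclopropyl on a nitrogen on an aromatic ring gives a 4.3-fold higher number from compound 3 to compound 4 (0.64 log units; beyond the scatter). The read-out therefore responds to the group on this nitrogen, with a modest step beyond the scatter, even though the exchange leaves the counts of hydrogen-bond donors and acceptors unchanged. No measured property bears on the reason for this rise.

The compounds shown leave open whether the step follows the ring or the added carbon link; cyclohexyl or cyclopropylmethyl on the same nitrogen would separate the two. Also open, on these data alone, is how a carboxylic acid in place of the ethyl ester would read with the cyclopropylamino group held fixed.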